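The source may report more compounds than this note shows. Statements on the series, on what has been measured and on what is new or still open speak of the compounds shown alone.

Measured compounds:
compound 1 `Cn1c(-c2cccs2)nnc1[S+](C)[O-]` gives > 200 mg/kg, a limit of the assay rather than a number.
compound 2 `Cn1c(-c2cccs2)nnc1S(C)(=O)=O` gives > 200 mg/kg, again only a limit.
compound 3 `Cn1c(-c2cccc3ccccc23)nnc1[S+](C)[O-]` gives > 200 mg/kg, again only a limit.

All three values come from a functional assay on the whole organism for antagonist activity, with Mus musculus as the target, in the maximal electroshock model; on this read-out higher numbers stand for an effect only at larger amounts of compound and lower numbers for an effect already at smaller amounts. The change from compound 1 to compound 2 is a group of 4 heavy atoms (1 carbon, 2 oxygen, 1 sulfur; no ring) in place of a group of 3 heavy atoms (1 carbon, 1 oxygen, 1 sulfur; no ring), on an aromatic carbon and yields a step that the two limits leave unreadable from compound 1 to compound 2. How the cores of compound 1 and compound 3 differ is not broken down here. Compound 4 `Cn1c(-c2cccc3ccccc23)nnc1S(C)(=O)=O` arises from compound 3 by the same kind of change, (a group of 4 heavy atoms (1 carbon, 2 oxygen, 1 sulfur; no ring) in place of a group of 3 heavy atoms (1 carbon, 1 oxygen, 1 sulfur; no ring), on an aromatic carbon); the surroundings differ only in the ring atom two ring bonds away, which on compound 3 bears a large group. Compound 4 is expected to give 250 mg/kg, within 120 mg/kg to 800 mg/kg, because of the limit of > 200 mg/kg in this assay, at which 3 of the 3 values shown sit. The step from compound 3 to compound 4 is expected to be a step that the limit leaves unreadable from compound 3 to compound 4.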

Compound 4, dose for half-maximal effect: > 200 mg/kg
Compound 4: a limit, no number (the forecaster's own chance of this, stated with the estimate: 85%); the middle value is on the limit's open side.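

No step can be read between compound 3 and compound 4, as each gives only a limit, not a number. The compounds shown leave open whether methylsulfonyl and the group it replaces differ at all in effect.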